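Ring swap from compound 3 to compound 4

A few compounds are considered here, and "the series" means these few. Any claim that something is new, unique, unknown or untested is made for them only; others in the source may bear on it.

- compound 1 `O=C(Nc1ccc(-c2cscn2)cc1)C1CCCN(Cc2ccc(F)c(F)c2)C1`: 1240 nM
- compound 2 `O=C(Nc1ccc(-c2cscn2)cc1)C1CCCN(Cc2cc(F)c(F)c(F)c2)C1`: 1260 nM
- compound 3 `O=C(Nc1ccc(-c2ccccn2)cc1)C1CCCN(Cc2ccc(F)c(F)c2)C1`: 11000 nM

All three values come from a functional assay on A-375 cells (Homo sapiens) for activation, with a stated time of 3 days; on this read-out lower numbers stand for an effect already at smaller amounts and higher numbers for an effect only at larger amounts of compound. Compound 3 stands highest of the three on this read-out. The fluoro change between the other two gives a 1.0-fold higher number from compound 1 to compound 2 (0.01 log units; within the scatter), and it concerns a different place from the next change.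

The next structure is compound 4 `O=C(Nc1ccc(-c2ncc[nH]2)cc1)C1CCCN(Cc2ccc(F)c(F)c2)C1`, where 1H-imidazol-2-yl replaces pyridin-2-yl on an aromatic carbon: 1H-imidazol-2-yl in place of pyridin-2-yl on an aromatic carbon.

For the measured compounds named here, the one measured step at this place is an 8.9-fold higher number from compound 1 to compound 3 (0.95 log units; beyond the scatter), with pyridin-2-yl in place of 1,3-thiazol-4-yl. Going by the values given here, compound 4 returns to a five-membered aromatic ring, as in compound 1 at 1240 nM, but no imidazolyl example has been measured, so only part of that step is expected to be recovered. The expected step, toward a lower number, is a 2.8-fold lower number from compound 3 to compound 4 (0.44 log units; beyond the scatter). For compound 4 the estimated value is 4000 nM, with an expected range from 1000 nM to 15000 nM.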

Compound 4, half-maximal effective concentration: 8000 nM
Estimate against measurement, compound 4: 2.0-fold (0.30 log units) below; the measured number falls inside the stated range.
By their numbers in this assay, from the lowest: compounds 1 and 2 (each within the scatter of the next); then compounds 4 and 3 (each within the scatter of the next).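

In this assay, exchanging the six-membered aromatic ring for the five-membered 1H-imidazol-2-yl, which brings in a hydrogen-bond donor, leaves the number within the scatter (a 1.4-fold lower number from compound 3 to compound 4 (0.14 log units; within the scatter)). A five-membered aromatic ring at this place, para to a large group, is therefore not enough in itself to reach the level of the 1,3-thiazol-4-yl group, and a clear gap remains to that group (a 6.5-fold higher number from compound 1 to compound 4 (0.81 log units; beyond the scatter)). Nothing on hand accounts for this gap.

Open, going by these compounds, is whether a 1,3-oxazol-4-yl or thiophen-2-yl group here, or a methyl group on the ring nitrogen of the 1H-imidazol-2-yl group, would come closer to compound 1. Also open, on these data alone, is whether the flat fluoro step from compound 1 to compound 2 carries over to compound 4.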